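Widening the Ring on Compound 2

A few compounds are considered here, and "the series" means these few. Any claim that something is new, unique, unknown or untested is made for them only; others in the source may bear on it.

In an ADME assay on the whole organism (Rattus norvegicus, strain Sprague-Dawley) for pharmacokinetics, read by LC-MS, with a stated time of 72 h, at a dose of 3 mg/kg by the oral route (a higher number here means more compound in the circulation at the dose given, a lower number less compound in the circulation), compound 1 `CN1CC[C@@H](N(c2cc(C#CC(C)(C)C)sc2C(=O)O)C(=O)[C@H]2CC[C@H](C)CC2)C1=O` gives 2950 nM, whereas compound 2 `CN1CC[C@H](N(c2cc(C#CC(C)(C)C)sc2C(=O)O)C(=O)[C@H]2CC[C@H](C)CC2)C1=O` gives 268 nM, the lower of the two numbers. This gap can only come from configuration because of the fact that compounds 1 and 2 differ only in the configuration as drawn. Compound 3 `CN1CCCC[C@@H](N(c2cc(C#CC(C)(C)C)sc2C(=O)O)C(=O)[C@H]2CC[C@H](C)CC2)C1=O` departs from compound 2 by one exchange on an amide-type nitrogen, with 1-methyl-2-oxoazepan-3-yl in place of 1-methyl-2-oxopyrrolidin-3-yl on an amide-type nitrogen. Within the data shown here, no measured step changes the ring size, so the evidence is indirect. The ring stereocentre of compound 3 is drawn in the same sense as in compound 1, the higher member of the pair. Among the measured compounds shown here, the only measured step, an 11-fold lower number from compound 1 to compound 2 (1.04 log units; beyond the scatter), is large and beyond the scatter, which shows how far configuration alone can move this number. The effect of the seven-membered ring is unmeasured. A rise is therefore expected, though a smaller one, and the estimated change is a 4.5-fold higher number from compound 2 to compound 3 (0.65 log units; beyond the scatter). For compound 3, the estimated maximal plasma concentration is 1200 nM, with an expected range of 280 nM to 4500 nM.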

Compound 3, maximal plasma concentration: 1250 nM
Compound 3: middle estimate off by 1.0-fold (0.02 log units), on the low side; the range from low to high includes it.
By their numbers in this assay, from the lowest: compound 2; then compound 3; then compound 1.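

Until this point, the only thing known about this position was that configuration alone can move the number: the fact that compounds 1 and 2 differ only in the configuration as drawn

Among these compounds, compound 3 gives the first reading on ring size. In this assay, the change to 1-methyl-2-oxoazepan-3-yl with the ring stereocentre drawn in the same sense gives a 2.4-fold lower number from compound 1 to compound 3 (0.37 log units; beyond the scatter), a modest step, whereas the change of configuration gave an 11-fold lower number from compound 1 to compound 2 (1.04 log units; beyond the scatter), a large one, so the position accepts the larger seven-membered ring at a modest cost in this number. The other step, a 4.7-fold higher number from compound 2 to compound 3 (0.67 log units; beyond the scatter), changes the ring size and the drawn sense together, so it cannot be credited to the wider ring alone.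

The compounds shown leave open whether the six-membered 1-methyl-2-oxopiperidin-3-yl would fall between the five- and seven-membered rings, and whether the seven-membered ring drawn in the opposite sense would lose as much as the five-membered ring did. An open-chain amide or an amine at this position also remains untested here, and a maximal plasma concentration alone cannot tell why any of these numbers differ.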